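A few compounds are considered here, and "the series" means these few. Any claim that something is new, unique, unknown or untested is made for them only; others in the source may bear on it.

Compound 2 `COC(=O)C1=C2C[C@@H]3CC[C@@H](C)[C@]2(CC1)C3(C)C` stands highest of the two numbers in an ADME assay on BJ cells (Homo sapiens) for cytotoxicity, read by CellTiter-Glo, with a stated time of 72 h; on this read-out lower numbers stand for an effect already at smaller amounts and higher numbers for an effect only at larger amounts of compound; in this assay compound 2 gives 26000 nM. Among the measured compounds shown here, its only neighbour is compound 1 `C[C@@H]1CC[C@H]2CC3=C(C(=O)O)CC[C@@]31C2(C)C`, which in this assay gives 1.3 nM; the step of a 20000-fold higher number from compound 1 to compound 2 (4.30 log units; beyond the scatter) comes from methyl in place of hydrogen on an oxygen next to a carbonyl group. Compound 3 `C[C@@H]1CC[C@H]2CC3=C(C=O)CC[C@@]31C2(C)C` is not yet measured in this assay. It differs from compound 2 by hydrogen in place of methoxy on a carbonyl carbon. For the measured compounds named here, the single measured step also altered the group on a carbonyl carbon and was large, so the new change at that site is not expected to be silent; whether compound 3 lands nearer compound 1 or compound 2 cannot be read from one step. The expected step is a 5.2-fold lower number from compound 2 to compound 3 (0.72 log units; beyond the scatter), a downward move carrying wide uncertainty. Compound 3 is estimated at 5000 nM, in the range 300 nM to 30000 nM.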

Compound 3, half-maximal effective concentration: 26000 nM
Estimate against measurement, compound 3: 5.2-fold (0.72 log units) below; measured number inside the range.
By their numbers in this assay, from the lowest: compound 1; then compounds 2 and 3 (each within the scatter of the next).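

In this assay, methoxycarbonyl to formyl on the double-bonded ring carbon gives no change at the digits printed from compound 2 to compound 3 (within the scatter) and so does not separate the methoxy from the hydrogen on this carbonyl carbon. Hydrogen in place of hydroxy gives a 20000-fold higher number from compound 1 to compound 3 (4.30 log units; beyond the scatter), a step as large as the one to the methyl ester, so two different replacements of the hydroxy both end at the same printed number and the low number stands with compound 1 alone. No measured information on the reason for this accompanies these compounds.

Open, going by these compounds, is whether a primary amide or a hydroxymethyl group on the double-bonded ring carbon would stay near compound 1 or join compounds 2 and 3. An ethyl ester would test whether the printed number holds for a longer chain on that oxygen.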